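Nitro in place of amino on the pyrimidin-2-yl analogue

This account rests on a few compounds, and the source may have more. Where it says the series, first, only, none or still open, it means among the compounds named here.

Values in an assay for displacement of a labelled ligand from Sigma non-opioid intracellular receptor 1 (Cavia porcellus) (a higher number here means a weaker inhibitor, a lower number a stronger inhibitor), so far:
compound 1 `COC(=O)C1(c2ccc([N+](=O)[O-])cc2)CC1CN1CCN(c2ccccn2)CC1` gives 769 nM.
compound 2 `COC(=O)C1(c2ccc(N)cc2)CC1CN1CCN(c2ncccn2)CC1` gives > 10000 nM, which is a limit of the assay.
compound 3 `COC(=O)C1(c2ccc(N)cc2)CC1CN1CCN(c2ccccn2)CC1` gives > 10000 nM, which is a limit of the assay.

Compound 2 thus stands at the limit of > 10000 nM in this assay, at which 2 of the 3 values shown sit, and no number is known for it; among the three values only compound 1 carries a number. Compound 4 `COC(=O)C1(c2ccc([N+](=O)[O-])cc2)CC1CN1CCN(c2ncccn2)CC1` is the unmeasured partner: nitro in place of amino on an aromatic carbon, so that compound 4 carries the pyrimidin-2-yl group of compound 2 together with the nitro group of compound 1.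

Going by the values given here, two measured steps touch this change. The same exchange run the other way on the pyridin-2-yl pair gave an at least 13-fold higher number from compound 1 to compound 3 (1.11 log units; beyond the scatter). The exchange of the ring on the amine nitrogen gave a step that the two limits leave unreadable from compound 2 to compound 3, so nothing can be read from it about how the pyrimidin-2-yl series sits against the pyridin-2-yl series.

On that basis a step of the same kind, towards a lower number, is expected from compound 2 to compound 4, on the order of an at least 6.6-fold lower number from compound 2 to compound 4 (0.82 log units; beyond the scatter), though the starting limit leaves its true size open. For compound 4 in this assay the estimate is 1500 nM, with a range from 300 nM to 10000 nM.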

Compound 4, inhibition constant: 619 nM
Beside the measured number, compound 4's estimate is 2.4-fold (0.38 log units) above it, within the range that was stated.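

In this assay, the change from 4-aminophenyl to 4-nitrophenyl now holds on two cores rather than only the pyridin-2-yl one, with an at least 16-fold lower number from compound 2 to compound 4 (1.20 log units; beyond the scatter), and the two steps do not separate: the same change on two cores in this assay, an at least 13-fold higher number (1.11 log units; beyond the scatter) from compound 1 to compound 3 and an at least 16-fold higher number (1.20 log units; beyond the scatter) from compound 4 to compound 2; the limit leaves it open whether they differ. Going by these compounds alone, with nitro in place, the exchange of the ring on the amine nitrogen can be read for the first time, and a 1.2-fold lower number from compound 1 to compound 4 (0.09 log units; within the scatter) shows that pyridin-2-yl and pyrimidin-2-yl do not separate in this pair. The same ring exchange between compound 2 and compound 3 cannot be read, and both of those values are limits, not numbers: the limit of > 10000 nM in this assay, at which 2 of the 4 values shown sit.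

As far as these compounds go, how far the amino compounds lie past that limit stays open, so the size of the change at this position is known only as a lower bound. Also open, from the compounds shown here alone, is whether the difference depends on nitro specifically or on the absence of amino, a question that a plain hydrogen, a nitrile or a methoxy group at the same position on the core of compound 4 would address.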